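Terminal phenyl change in the urea-linked pyrazole series

The compounds below may be only part of what the source reports. "The series", "measured", "known", "first", "only" and "open" are said of these compounds alone.

Compound 3 `COc1cc(Cl)cc(-c2nn(-c3cccc(NC(=O)Nc4ccc(Cl)c(Cl)c4)c3)cc2-c2ccncc2)c1` gives -9% in a functional assay on HCT-15 cells (Homo sapiens) for inhibition, read by sulforhodamine B assay, with a stated time of 48 h, tested at 100 uM (on this read-out lower numbers stand for a stronger effect and higher numbers for a weaker effect at the one concentration tested), the highest of the three numbers measured. Compound 1 `COc1cc(Cl)cc(-c2nn(-c3cccc(NC(=O)Nc4ccc(Cl)c(C(F)(F)F)c4)c3)cc2-c2ccncc2)c1` gives -90% in this assay, and compound 2 `COc1cc(Cl)cc(-c2nn(-c3cccc(NC(=O)Nc4cc(C(F)(F)F)cc(C(F)(F)F)c4)c3)cc2-c2ccncc2)c1` gives -83%. Within the data shown here, the one single-point step on record is a number 81 percentage points higher from compound 1 to compound 3 (beyond the scatter), so exchanging trifluoromethyl for chloro on the terminal phenyl went with a large loss of effect.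

Compound 4 `COc1cc(Cl)cc(-c2nn(-c3cccc(NC(=O)Nc4cccc(C(F)(F)F)c4)c3)cc2-c2ccncc2)c1` is not yet measured; it differs from compound 3 by 3-(trifluoromethyl)phenyl in place of 3,4-dichlorophenyl on an amide-type nitrogen. This reverses the step just described and also removes the second chloro. Compound 2, which carries trifluoromethyl and no chloro on that ring, shows an effect close to that of compound 1, so the absence of chloro alone is not expected to weaken the read-out.

Compound 4 is therefore expected to move back toward the range of compounds 1 and 2, an expected step of a number 61 percentage points lower from compound 3 to compound 4 (beyond the scatter). The estimate for compound 4 in this assay is -70%, with a range from -95% to -20%.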

Compound 4, a percentage reported as activity, at one concentration (the size of the read-out at that concentration, not a potency): -72%
The estimate for compound 4 lay 2 percentage points above the measured number, and the stated range covers the measured number.
By their numbers in this assay, from the lowest: compounds 1 and 2 (each within the scatter of the next); then compound 4; then compound 3.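

In this assay the terminal ring on the amide-type nitrogen gives a number 63 percentage points lower from compound 3 to compound 4 (beyond the scatter) and so a strong read-out needs no chloro there, provided trifluoromethyl is present. A second group on 3-(trifluoromethyl)phenyl adds only a modest amount, whether it is a second trifluoromethyl, as a number 11 percentage points higher from compound 2 to compound 4 (beyond the scatter) shows, or a chloro, as a number 18 percentage points higher from compound 1 to compound 4 (beyond the scatter) shows, so among these compounds the single trifluoromethyl accounts for most of the effect. No measurement on hand bears on why this ring behaves this way.

Open, as far as these compounds go, is how a nitrile, a methoxy group or a carboxylic acid would read in place of trifluoromethyl on this ring. Also open, from the compounds shown here alone, is how much effect a plain phenyl on the same nitrogen would keep.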